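Adding two chlorines to the pendant phenyl of compound 1

The source may hold more compounds than are shown below. What is called first, only, known or untested is meant among the compounds shown, and "the series" means these compounds.

Three compounds share one core and differ only in the ring hanging from it. Compound 1 `COc1cc2c(Oc3ccc(NC(=O)c4cc(-c5ccccc5)nc5ccccc45)cc3F)ccnc2cc1OCCCN1CCCCC1` carries an unsubstituted phenyl; in a functional assay on MKN-45 cells (Homo sapiens) for cytotoxicity, read by MTT assay, with a stated time of 72 h (a higher number here means a weaker inhibitor, a lower number a stronger inhibitor), compound 1 gives 15 nM. Compound 2 `COc1cccc(-c2cc(C(=O)Nc3ccc(Oc4ccnc5cc(OCCCN6CCCCC6)c(OC)cc45)c(F)c3)c3ccccc3n2)c1` gives 360 nM, and compound 3 `COc1cc2c(Oc3ccc(NC(=O)c4cc(-c5cccc(Cl)c5)nc5ccccc45)cc3F)ccnc2cc1OCCCN1CCCCC1` gives 11 nM. Among these three numbers compound 1 stands second highest: the step of a 1.4-fold lower number from compound 1 to compound 3 (0.13 log units; within the scatter) lies within the scatter, whereas the step of a 24-fold higher number from compound 1 to compound 2 (1.38 log units; beyond the scatter) is large and beyond it, as is the step of a 33-fold lower number from compound 2 to compound 3 (1.51 log units; beyond the scatter).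

Compound 4 `COc1cc2c(Oc3ccc(NC(=O)c4cc(-c5ccc(Cl)c(Cl)c5)nc5ccccc45)cc3F)ccnc2cc1OCCCN1CCCCC1` has not yet been measured. Relative to compound 1 it shows the change (3,4-dichlorophenyl in place of phenyl on an aromatic carbon). The step that bears most directly on this is a 1.4-fold lower number from compound 1 to compound 3 (0.13 log units; within the scatter), since a single chloro on that ring left the number essentially unchanged. Nothing in the data shows what a second chloro does, so the expectation for compound 4 in this assay is a step of a 1.4-fold lower number from compound 1 to compound 4 (0.13 log units; within the scatter), that is, no change beyond the scatter. Compound 4 is therefore estimated at 11 nM, with a range from 4 nM to 30 nM.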

Compound 4, half-maximal inhibitory concentration: 730 nM
The estimate for compound 4 lay 66-fold (1.82 log units) below the measured number; measured number outside the range, above it.
By their numbers in this assay, from the lowest: compounds 3 and 1 (each within the scatter of the next); then compound 2; then compound 4.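

In this assay, 3,4-dichlorophenyl in place of phenyl gives a 49-fold higher number from compound 1 to compound 4 (1.69 log units; beyond the scatter) and so shows that this ring does not accept every chloro substitution equally. A second chloro on the ring gives a 66-fold higher number from compound 3 to compound 4 (1.82 log units; beyond the scatter) even though the first left the number within the scatter, so the effect of chloro groups here is not simply additive. The 3,4-dichlorophenyl ring also lies beyond the 3-methoxyphenyl ring, with a 2.0-fold higher number from compound 2 to compound 4 (0.31 log units; beyond the scatter) as a modest step, so two of the three substituted rings shown bring large losses against phenyl, while the single chloro goes against that pattern.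

Nothing available explains why the second chloro has such a large effect. The compounds shown also leave open how this ring would respond to a fluoro, an amine or a carboxylic acid in place of the chloro groups.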